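Furan-2-yl ketone replacing cyclopropyl ketone on the bicyclic amine

The source may hold more compounds than are shown below. What is called first, only, known or untested is meant among the compounds shown, and "the series" means these compounds.

The series is followed in an assay on SHEP1 cells for displacement of a labelled ligand from Neuronal acetylcholine receptor; alpha4/beta2 (Homo sapiens), read by scintillation counting, with a stated time of 2 h; a higher number here means a weaker inhibitor, a lower number a stronger inhibitor. Of the compounds shown here, two carry numbers so far. Compound 1 `COC(=O)[C@H]1C[C@H]2CNC[C@H]2C1` gives 8 nM in this assay. Compound 2 `O=C(C1CC1)[C@H]1C[C@@H]2CNC[C@@H](C2)C1` gives 43 nM in this assay, the higher of the two numbers; the gap to compound 1 lies beyond the usual scatter of the measurement, so compound 2 is the weaker of the two measured inhibitors. Within the data shown here, compound 1 and compound 2 differ in more than one place, so no single step between them can be read off.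

Compound 3 `O=C(c1ccco1)[C@H]1C[C@@H]2CNC[C@@H](C2)C1` is the next compound for this assay. It differs from compound 2 in one place: furan-2-yl in place of cyclopropyl on a carbonyl carbon. Among the measured compounds shown here, no measured pair shows a change of this kind, so there is nothing in the numbers to set its size or direction. The working expectation for the step from compound 2 to compound 3 is a small one, a 1.4-fold lower number from compound 2 to compound 3 (0.16 log units; within the scatter), within or only just beyond the scatter, with the direction left open. Compound 3 is therefore estimated at 30 nM in this assay, with a range from 8 nM to 120 nM.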

Compound 3, inhibition constant: 110 nM
For compound 3 the middle estimate is 3.7-fold (0.56 log units) below the measured one, and the stated range covers the measured number.
By their numbers in this assay, from the lowest: compound 1; then compound 2; then compound 3.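

In this assay the group on the carbonyl carbon, whose other neighbour is a saturated ring carbon, proves to matter: furan-2-yl in place of cyclopropyl gives a 2.6-fold higher number from compound 2 to compound 3 (0.41 log units; beyond the scatter) as a modest step on an otherwise unchanged core. Among these compounds, this is the first change that can be read in one place, and it gives this position a measured direction, with the swap to a five-membered aromatic ring carrying one hydrogen-bond acceptor going against binding strength rather than leaving it within the scatter. No measurement at hand bears on the reason for this step.

From the compounds shown here alone, a single step changes ring size, aromatic character and the oxygen atom all at once, so it remains open which of these goes with the higher number. Phenyl, thiophen-2-yl, tetrahydrofuran-2-yl or an open chain such as isopropyl on the same carbonyl carbon would pull these features apart and show whether cyclopropyl is a favourable group here or furan-2-yl an unfavourable one.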